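This account rests on a few compounds, and the source may have more. Where it says the series, first, only, none or still open, it means among the compounds named here.

Measured so far in a functional assay on SH-SY5Y cells (Homo sapiens) for cytotoxicity, read by MTT assay, with stated times of 24 h and 4 h; a lower number here means that less compound is needed, a higher number that more compound is needed for the effect:
compound 1 `COc1cc(/C=C/C(=O)NCc2ccc(OCc3nc(C)c(C)nc3C)c(OC)c2)ccc1O` — 13400 nM
compound 2 `COc1cc(/C=C/C(=O)NCc2ccc(OCc3nc(C)c(C)nc3C)c(OC)c2)ccc1OCc1nc(C)c(C)nc1C` — 11100 nM

Among the compounds with values here, compound 1 stands highest of the two numbers in this assay, with compound 2 nearest, and the one measured step, a 1.2-fold lower number from compound 1 to compound 2 (0.08 log units; within the scatter), lies within the scatter. Compound 3 `COc1cc(CNC(=O)/C=C/c2cccc(OC)c2OC)ccc1OCc1nc(C)c(C)nc1C` differs from compound 1 in one place: 2,3-dimethoxyphenyl in place of 4-hydroxy-3-methoxyphenyl on a double-bonded chain carbon bound to a double-bonded chain carbon. Within the data shown here, no measured step changes this part of the core in the same way. Among the measured compounds shown here, the only step available touches the oxygen on the aromatic ring of the group that leaves, and it shows nothing beyond the scatter, so the weight of that group on the read-out appears small on present evidence. The expectation for compound 3 is therefore a step of a 1.1-fold lower number from compound 1 to compound 3 (0.03 log units; within the scatter), that is none beyond the scatter. Compound 3 is estimated at 12500 nM in this assay, with a range from 5000 nM to 32000 nM.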

Compound 3, half-maximal effective concentration: 7150 nM
Estimate against measurement, compound 3: 1.7-fold (0.24 log units) above; measured number inside the range.
By their numbers in this assay, from the lowest: compounds 3, 2 and 1 (each within the scatter of the next).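

Within the data shown here, exchanging 4-hydroxy-3-methoxyphenyl for 2,3-dimethoxyphenyl on a double-bonded chain carbon bound to a double-bonded chain carbon gives, in this assay, a 1.9-fold lower number from compound 1 to compound 3 (0.27 log units; within the scatter), the first reading on this aromatic ring itself. The entering group has no hydrogen-bond donor, so the free hydroxy of compound 1 can be lost here, together with a rearrangement of the ring substituents, without a step beyond the scatter, as was already seen when that hydroxy was capped in compound 2. No evidence on the basis of this result is at hand.

Going by these compounds, whether an amine or a carboxylic acid on this aromatic ring would move the number beyond the scatter stays open. The separate contribution of each methoxy group of 2,3-dimethoxyphenyl also remains unresolved.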